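Swapping Methoxy for Methyl on the Amide-Bearing Ring

This account rests on a few compounds, and the source may have more. Where it says the series, first, only, none or still open, it means among the compounds named here.

Compound 1 `COc1ccc2c(=O)c(/C=C/C(=O)Nc3ccc(C)cc3)coc2c1`: 39300 nM in a functional assay (QGY7701 cells, Homo sapiens) for inhibition, read by MTT assay, with a stated time of 48 h; on this read-out lower numbers stand for stronger inhibition and higher numbers for weaker inhibition
Compound 2 `COc1ccc2c(=O)c(/C=C/C(=O)Nc3ccccc3)coc2c1`: 14000 nM
Compound 3 `COc1cccc(NC(=O)/C=C/c2coc3cc(OC)ccc3c2=O)c1`: 39100 nM

Compound 3 stands second highest of the three numbers; compound 1 lies within the scatter of it, while compound 2 sits lower, as a 2.8-fold higher number from compound 2 to compound 3 (0.45 log units; beyond the scatter) shows. Compound 4 `COc1ccc2c(=O)c(/C=C/C(=O)Nc3cccc(C)c3)coc2c1` differs from compound 3 by methyl in place of methoxy on an aromatic carbon. Going by the values given here, two measured steps bear on this. The step of a 2.8-fold lower number from compound 1 to compound 2 (0.45 log units; beyond the scatter) and the step of a 2.8-fold higher number from compound 2 to compound 3 (0.45 log units; beyond the scatter) both show that the bare ring of compound 2 gives the lowest number, and that adding either a methyl or a methoxy to that ring raises it modestly. Compound 4 keeps a small group on the ring, so its number is expected to stay near that of compound 3, with a step of a 1.3-fold lower number from compound 3 to compound 4 (0.12 log units; within the scatter) not beyond the scatter. Compound 4 is therefore estimated at 30000 nM, in the range 12000 nM to 75000 nM.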

Compound 4, half-maximal inhibitory concentration: > 100000 nM
Compound 4: a limit, no number; the forecaster's own chance of this, stated with the estimate: 5%; middle value at least 3.3-fold (0.52 log units) away from the limit.
By their numbers in this assay, from the lowest: compound 2; then compounds 3 and 1 (each within the scatter of the next). At a limit, above all of these: compound 4.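

Compound 4 gives only > 100000 nM, which is a limit of the assay and not a number. Methyl and methoxy are therefore not interchangeable at this place on the ring, as replacing one with the other gives an at least 2.5-fold higher number from compound 3 to compound 4 (0.40 log units; beyond the scatter). The methyl's place also matters, since 3-methylphenyl in place of 4-methylphenyl gives an at least 2.5-fold higher number from compound 1 to compound 4 (0.40 log units; beyond the scatter), and methyl in place of hydrogen gives an at least 7.1-fold higher number from compound 2 to compound 4 (0.85 log units; beyond the scatter).

As far as these compounds go, how far compound 4 lies past its limit stays unknown. From the compounds shown here alone, it also remains open how an amine or a carboxylic acid would read at this place on the ring.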